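Swapping methyl for methoxy on a low-toxicity series

The compounds below may be only part of what the source reports. "The series", "measured", "known", "first", "only" and "open" are said of these compounds alone.

Values measured in an ADME assay on HepG2 2.2.15 cells (Homo sapiens) for cytotoxicity, read by MTT assay, with a stated time of 8 days; on this read-out higher numbers stand for lower toxicity in this test and lower numbers for higher toxicity in this test:
- Compound 1 `COC(=O)c1cc(-c2ccc(F)nc2F)nn(Cc2ccc(Cl)cc2)c1=O`: > 100000 nM, a limit of the assay and not a number
- Compound 2 `CC(C)c1cc(-c2ccc(F)nc2F)nn(Cc2ccc(Cl)cc2)c1=O`: 56700 nM
- Compound 3 `Cc1cc(-c2ccc(F)nc2F)nn(Cc2ccc(Cl)cc2)c1=O`: 83800 nM

Compound 3 has the highest of the two true numbers, but the gap to compound 2 is small: a 1.5-fold higher number from compound 2 to compound 3 (0.17 log units; within the scatter). The next compound, compound 4 `COc1cc(-c2ccc(F)nc2F)nn(Cc2ccc(Cl)cc2)c1=O`, carries methoxy in place of methyl on an aromatic carbon.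

This group has not yet been tested, so the nearest guide is what other swaps on the same carbon did. Among the measured compounds shown here, three steps bear on it. The first is a 1.5-fold higher number from compound 2 to compound 3 (0.17 log units; within the scatter). The two others start from the limit and are only floors: an at least 1.7-fold lower number from compound 1 to compound 2 (0.24 log units; that floor lies within the scatter), and an at least 1.1-fold lower number from compound 1 to compound 3 (0.07 log units; that floor lies within the scatter). None of them goes beyond the scatter, so no step beyond the scatter is expected in this assay. The expected change is a 1.0-fold lower number from compound 3 to compound 4 (0.02 log units; within the scatter). The top of the range below meets (the limit of > 100000 nM in this assay, at which 1 of the 3 values shown sits), so compound 4 could also return only a limit. For compound 4 the estimated value is 80000 nM, with an expected range from 45000 nM to 100000 nM.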

Compound 4, half-maximal cytotoxic concentration: 92200 nM
The estimate for compound 4 lay 1.2-fold (0.06 log units) below the measured number; measured number inside the range.
By their numbers in this assay, from the lowest: compounds 2, 3 and 4 (each within the scatter of the next). At a limit, above all of these: compound 1.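

In this assay, this carbon now also tolerates a group that brings in an oxygen and a hydrogen-bond acceptor, and the number does not move: a 1.1-fold higher number from compound 3 to compound 4 (0.04 log units; within the scatter). The swap from isopropyl also stays inside the scatter (a 1.6-fold higher number from compound 2 to compound 4 (0.21 log units; within the scatter)), and the swap from methoxycarbonyl gives only a floor (an at least 1.0-fold lower number from compound 1 to compound 4 (0.03 log units; that floor lies within the scatter)). Compound 1 gives a limit and not a number: the limit of > 100000 nM in this assay, at which 1 of the 4 values shown sits.

As far as these compounds go, whether an amine, a carboxylic acid or a longer chain on this carbon would shift the number beyond the scatter stays open. Also open, from the compounds shown here alone, is whether this flat picture would hold with something other than the 4-chlorobenzyl group or the 2,6-difluoropyridin-3-yl group on the shared core, as all four compounds carry both.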